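The source may report more compounds than this note shows. Statements on the series, on what has been measured and on what is new or still open speak of the compounds shown alone.

Compound 1 `COC(=O)c1cccc(C2C(C(=O)O)=C(C)N=C(C)/C2=C(/O)OC/C=C/c2ccccc2)c1` gives 4400 nM in a functional assay on thoracic aorta for inhibition of Voltage-gated L-type calcium channel (Rattus norvegicus); on this read-out higher numbers stand for weaker inhibition and lower numbers for stronger inhibition. Compound 2 `CC1=NC(C)=C(C(=O)O)C(c2cccc(C(=O)O)c2)/C1=C(\O)OC/C=C/c1ccccc1` returns only a limit in this assay, > 10000 nM; this is the limit of > 10000 nM in this assay, at which 1 of the 2 values shown sits. Among the measured compounds shown here, the step of an at least 2.2-fold higher number from compound 1 to compound 2 (0.35 log units; beyond the scatter) is thus a lower bound, and it is the only measured step. Compound 3 `CC1=NC(C)=C(C(=O)O)C(c2cccnc2)/C1=C(\O)OC/C=C/c1ccccc1` differs from compound 2 by pyridin-3-yl in place of 3-carboxyphenyl on a saturated ring carbon. For the measured compounds named here, no measured step alters the group on the saturated ring carbon, so the step from compound 1 to compound 2 bears on this change only indirectly: compound 3 carries no carboxy group on the entering ring, and the comparison of compound 1 with compound 2 shows the free carboxy group on that ring accompanying weaker inhibition. Compound 3 is expected to return into the measurable range, at about 3000 nM, between 800 nM and 10000 nM. The expected step is an at least 3.3-fold lower number from compound 2 to compound 3 (0.52 log units; beyond the scatter).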

Compound 3, half-maximal inhibitory concentration: 190 nM
Estimate against measurement, compound 3: 16-fold (1.20 log units) above, outside the stated range (below it).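

Changing the aromatic group itself on the saturated ring carbon, and not only the ending of its substituent, moves the read-out in this assay: pyridin-3-yl in place of 3-carboxyphenyl gives an at least 52-fold lower number from compound 2 to compound 3 (1.72 log units; beyond the scatter), which is a lower bound. Compound 2 stands at a limit and not at a number: the limit of > 10000 nM in this assay, at which 1 of the 3 values shown sits. Pyridin-3-yl in place of 3-(methoxycarbonyl)phenyl, with numbers at both ends, gives a 23-fold lower number from compound 1 to compound 3 (1.36 log units; beyond the scatter), so the large gain does not rest on the limit or on the free carboxy group of compound 2 alone.

The compounds shown leave open whether the ring nitrogen of pyridin-3-yl or the absence of a ring substituent carries this gain; an unsubstituted phenyl at this carbon would separate the two. Also open, as far as these compounds go, is the role of the carboxy group on the core, present in all three compounds, which a methyl ester or an amide there would test.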